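Stereochemical definition at the benzyl-bearing carbon of compound 1

The source may hold more compounds than are shown below. What is called first, only, known or untested is meant among the compounds shown, and "the series" means these compounds.

Measured compounds in an assay on isolated protein for inhibition of Pepsin A (Sus scrofa); a higher number here means a weaker inhibitor, a lower number a stronger inhibitor:
- compound 1 `CC(C)CCNC(=O)C(C)NC(=O)C(Cc1ccccc1)C[C@H](O)[C@H](CC(C)C)NC(=O)C(NC(=O)CC(C)C)C(C)C`: 2.5 nM
- compound 2 `CC(C)CCNC(=O)C(C)NC(=O)C(C)C[C@H](O)[C@H](CC(C)C)NC(=O)C(NC(=O)CC(C)C)C(C)C`: 3 nM
- compound 3 `CC(C)CCNC(=O)C(C)NC(=O)C(C)CC(=O)[C@H](CC(C)C)NC(=O)C(NC(=O)CC(C)C)C(C)C`: 27 nM

Compound 1 gives the lowest number of the three in this assay. Its nearest neighbour is compound 2, and the step of a 1.2-fold higher number from compound 1 to compound 2 (0.08 log units; within the scatter) lies within the scatter, so the two cannot be ordered. Compound 3 sits furthest away; its value against that of compound 1 is a gap well beyond the scatter, and the pair differs only in the hydroxyl carbon of compound 2 being a carbonyl in compound 3, a change unrelated to the present one.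

The step to compound 4 `CC(C)CCNC(=O)C(C)NC(=O)[C@H](Cc1ccccc1)C[C@H](O)[C@H](CC(C)C)NC(=O)C(NC(=O)CC(C)C)C(C)C` is the two compounds have the same atoms and bonds; at least one stereo element is drawn with a configuration in one of them and without one in the other: 1 of 5 stereo elements differ; a stereocentre at a saturated chain carbon is drawn without a configuration in compound 1 and R in compound 4. Going by the values given here, no measured step bears directly on fixing a configuration; the only step at this carbon, a 1.2-fold higher number from compound 1 to compound 2 (0.08 log units; within the scatter), removes the phenyl group altogether and stays within the scatter. With nothing else entering or leaving, the expected step of a 1.3-fold lower number from compound 1 to compound 4 (0.10 log units; within the scatter) is none beyond the scatter, with the defined epimer allowed a modest shift in either direction. Compound 4 is therefore estimated at 2 nM, within a range of 0.8 nM to 6 nM.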

Compound 4, inhibition constant: 140 nM
For compound 4 the middle estimate is 70-fold (1.85 log units) below the measured one, and the stated range ends below it.
By their numbers in this assay, from the lowest: compounds 1 and 2 (each within the scatter of the next); then compound 3; then compound 4.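

In this assay the new step is a 56-fold higher number from compound 1 to compound 4 (1.75 log units; beyond the scatter), and no atom or bond enters or leaves. Going by these compounds alone, the only earlier step at this saturated chain carbon, a 1.2-fold higher number from compound 1 to compound 2 (0.08 log units; within the scatter), stayed within the scatter and gave no sign that the position was sensitive, whereas the drawn R configuration here is tied to a large loss: the position tolerates losing the phenyl group, yet compound 4, which keeps it, gives a far higher number. The gap between the two compounds can be traced to one thing only, so the low number of compound 1 cannot be credited to the R form at this carbon: the fact that one of compounds 1 and 4 is drawn with a defined configuration and the other without, at the place where they differ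

Still open, from the compounds shown here alone, is whether compound 1 is a mixture at this carbon or a single form, and so what number the S form would give and how much of the value of compound 1 it carries. Also open, going by these compounds, is whether configuration at this carbon weighs as heavily with the smaller group of compound 2, or with a cyclohexylmethyl group in place of the benzyl group.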